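Replacing the Tetrazole of Compound 3 with an Ethyl Ester

The source may hold more compounds than are shown below. What is called first, only, known or untested is meant among the compounds shown, and "the series" means these compounds.

Three compounds share one core and differ only in the group hanging from the phenyl ether. Compound 1 `c1ccc2nc(COc3ccc(Cc4nnn[nH]4)cc3)ccc2c1` gives 275 nM in an assay on isolated protein for binding affinity to cysteinyl leukotriene receptor 1 (Cavia porcellus) (on this read-out higher numbers stand for weaker inhibition and lower numbers for stronger inhibition), compound 2 `c1ccc2nc(COc3ccc(SCCCc4nnn[nH]4)cc3)ccc2c1` gives 31 nM, and compound 3 `c1ccc2nc(COc3ccc(OCCCc4nnn[nH]4)cc3)ccc2c1` gives 69 nM. The steps among them are modest: an 8.9-fold lower number from compound 1 to compound 2 (0.95 log units; beyond the scatter), a 4.0-fold lower number from compound 1 to compound 3 (0.60 log units; beyond the scatter) and a 2.2-fold higher number from compound 2 to compound 3 (0.35 log units; beyond the scatter). Compound 3 therefore stands second highest of the three, closer to compound 2 than to compound 1.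

Compound 4 `CCOC(=O)CCCOc1ccc(OCc2ccc3ccccc3n2)cc1` differs from compound 3 in one place: ethoxycarbonyl in place of 1H-tetrazol-5-yl on a saturated chain carbon, three bonds along the chain from an oxygen on an aromatic ring. For the measured compounds named here, every measured compound carries a tetrazole, and compound 4 is the first without one, so no measured step bears on this change; the three steps above only shift the linker between the phenyl ether and the tetrazole. The estimate rests on the structural change alone and is held wide. A clearly weaker result is expected, a 43-fold higher number from compound 3 to compound 4 (1.64 log units; beyond the scatter). Compound 4 is estimated at 3000 nM in this assay, within a range of 300 nM to 30000 nM.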

Compound 4, inhibition constant: 500 nM
Compound 4: middle estimate off by 6.0-fold (0.78 log units), on the high side; the measured number falls inside the stated range.
By their numbers in this assay, from the lowest: compound 2; then compound 3; then compounds 1 and 4 (each within the scatter of the next).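

Swapping 1H-tetrazol-5-yl for ethoxycarbonyl at this chain end costs binding in this assay with a 7.2-fold higher number from compound 3 to compound 4 (0.86 log units; beyond the scatter) and no more than that, so a compound with no tetrazole at all still gives a measurable number. Set against the sulfur-containing chain of compound 2, the change is large, with a 16-fold higher number from compound 2 to compound 4 (1.21 log units; beyond the scatter) and a clear loss, whereas a 1.8-fold higher number from compound 1 to compound 4 (0.26 log units; within the scatter) leaves compound 4 level with compound 1 and its (1H-tetrazol-5-yl)methyl group. Nothing measured here explains why the number moves with this swap.

The compounds shown leave open how a carboxylic acid would read in place of the ethoxycarbonyl on this same chain. They also leave open whether a longer chain, or sulfur in place of the chain oxygen, would change the result for the ethyl ester.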